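The source may hold more compounds than are shown below. What is called first, only, known or untested is meant among the compounds shown, and "the series" means these compounds.

Working notes on the series. Compound 3 `CCCOc1nc2c(c(=O)n(C)c(=O)n2C)n1CCCN1CCN(c2ccccc2)CC1` stands highest of the three numbers in an assay on cell membranes (strain Wistar) for displacement of a labelled ligand from 5-hydroxytryptamine receptor 7 (Rattus norvegicus); on this read-out lower numbers stand for stronger inhibition and higher numbers for weaker inhibition: compound 3 gives 980 nM. Compound 1 `CCOc1nc2c(c(=O)n(C)c(=O)n2C)n1CCCN1CCN(c2ccccc2OC)CC1` is nearest, giving 410 nM, and compound 2 `CCOc1nc2c(c(=O)n(C)c(=O)n2C)n1CCCN1CCN(c2cccc(Cl)c2)CC1` is furthest, giving 130 nM. Among the measured compounds shown here, the one single-point step among the measured compounds, a 3.2-fold lower number from compound 1 to compound 2 (0.50 log units; beyond the scatter), concerns the aryl group on the amine nitrogen in the ring.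

Compound 4 `CCCOc1nc2c(c(=O)n(C)c(=O)n2C)n1CCCN1CCN(c2ccccc2OC)CC1` differs from compound 3 by methoxy in place of hydrogen on an aromatic carbon. For the measured compounds named here, no measured pair shows this exact change on its own. Compound 1 and compound 3 differ in two places, the alkoxy chain on the core and the aryl group, so the value of compound 1, 410 nM, set against that of compound 3, 980 nM, only hints that the 2-methoxyphenyl compound sits lower. On that basis a modest step downward, at or somewhat beyond the scatter, is expected from compound 3 to compound 4, a 2.0-fold lower number from compound 3 to compound 4 (0.29 log units; within the scatter). Compound 4 is estimated at 500 nM in this assay, with a range from 200 nM to 1300 nM.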

Compound 4, inhibition constant: 328 nM
Estimate against measurement, compound 4: 1.5-fold (0.18 log units) above, and the stated range covers the measured number.
By their numbers in this assay, from the lowest: compound 2; then compounds 4 and 1 (each within the scatter of the next); then compound 3.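

Methoxy in place of hydrogen on an aromatic carbon, ortho to a large group, now has a direct single-point reading in this assay: a 3.0-fold lower number from compound 3 to compound 4 (0.48 log units; beyond the scatter), a step beyond the scatter that the earlier compounds could only hint at. The alkoxy chain on the core also gets its first single-point reading, with the 2-methoxyphenyl group held fixed: methyl in place of hydrogen on the saturated chain carbon gives a 1.3-fold lower number from compound 1 to compound 4 (0.10 log units; within the scatter), which is within the scatter. Nothing available bears on the cause of either step.

Still open, on these data alone, is whether an ethoxy or hydroxy group on that aromatic carbon would give a comparable step, and whether a butoxy chain on the core would also stay within the scatter. As far as these compounds go, how the 3-chlorophenyl group of compound 2 behaves with a different chain on the core also remains open.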